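Pyridin-2-yl on the central carbon of a diallyl bisphenol scaffold

This account rests on a few compounds, and the source may have more. Where it says the series, first, only, none or still open, it means among the compounds named here.

Measured compounds:
- compound 1, `C=CCc1cc(Cc2ccc(O)c(CC=C)c2)ccc1O`: 74%
- compound 2, `C=CCc1cc(C(=C(Cl)Cl)c2ccc(O)c(CC=C)c2)ccc1O`: 76%

Of the compounds shown here, two have so far been tested in a functional assay on SVR cells (Mus musculus) for antiproliferative activity, with a stated time of 72 h, tested at 15 ug/mL; on this read-out higher numbers stand for a stronger effect at the one concentration tested and lower numbers for a weaker effect. Compound 1 gives 74% in this assay, which is the lower of the two numbers, and compound 2 gives 76%. The two values lie within the scatter of each other, so on these numbers the two compounds cannot be told apart; both show a substantial effect at the one concentration used.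

Compound 3, `C=CCc1cc(C(c2ccc(O)c(CC=C)c2)c2ccccn2)ccc1O`, has not yet been measured in this assay. It shares the core of compound 1 and differs from it in one place: pyridin-2-yl in place of hydrogen on a saturated chain carbon bound to two aromatic carbons. For the measured compounds named here, compound 2 carries its own substitution at that same saturated chain carbon, and its value in this assay sits within the scatter of compound 1, which is the only guide available for a change at this position.

Going by the values given here, no step in this assay is expected to exceed the scatter, so for compound 3 the estimated step of a number 2 percentage points lower from compound 1 to compound 3 (within the scatter) is essentially none. Compound 3 is therefore expected to give about 72% in this assay, within a range from 55% to 88%.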

Compound 3, a percentage reported as inhibition, at one concentration (the size of the read-out at that concentration, not a potency): 46%
Compound 3: middle estimate off by 26 percentage points, on the high side; the measured number lies below the stated range.
By their numbers in this assay, from the lowest: compound 3; then compounds 1 and 2 (each within the scatter of the next).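

The position turns out not to be indifferent to what it carries: in this assay, pyridin-2-yl in place of hydrogen on a saturated chain carbon bound to two aromatic carbons brings a number 28 percentage points lower from compound 1 to compound 3 (beyond the scatter). Compound 2 had suggested otherwise. With its own substitution at that same carbon, compound 2 gives 76%, within the scatter of compound 1 at 74%. A change at this carbon can therefore leave the number where it was or lower it, depending on the group, and nothing available here accounts for the effect of pyridin-2-yl.

The compounds shown leave open whether the loss belongs to the aromatic ring as such or to its nitrogen, a question that a phenyl group on the same carbon would help to settle. They also leave open how a small group such as methyl, or a group such as aminomethyl, would fare there, and whether the loss seen at this single concentration would hold at other concentrations.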